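Dropping one benzyl from the amide nitrogen

A few compounds are considered here, and "the series" means these few. Any claim that something is new, unique, unknown or untested is made for them only; others in the source may bear on it.

In an ADME assay on HEK-293T cells (Homo sapiens) for cytotoxicity, read by CCK-8 assay, with a stated time of 24 h (a lower number here means that less compound is tolerated, a higher number that more compound is tolerated), compound 1, with structure `Cn1cc(SCC(=O)N(Cc2ccccc2)Cc2ccccc2)c2ccccc21`, gives 91200 nM. That is the lower of the two numbers in hand, but the nearest neighbour, compound 3, with structure `COc1ccccc1CNC(=O)CSc1c[nH]c2c(-c3ccccc3)cccc12`, gives 95500 nM, a gap that stays within the scatter, so the two cannot be told apart. Compound 2, with structure `CN(Cc1ccccc1)C(=O)CSc1c[nH]c2ccccc12`, returns only a limit, > 100000 nM, which is the limit of > 100000 nM in this assay, at which 1 of the 3 values shown sits. Compound 4, with structure `Cn1cc(SCC(=O)NCc2ccccc2)c2ccccc21`, has not yet been measured in this assay. It differs from compound 1 in one place: hydrogen in place of benzyl on an amide-type nitrogen. Among the measured compounds shown here, no pair of measured compounds differs by just this change, so the size of the step can only be judged from the three values at hand, all of which sit close to one another or at the limit. A small step is expected, a 1.1-fold higher number from compound 1 to compound 4 (0.04 log units; within the scatter), in no clear direction beyond the scatter. Compound 4 is therefore estimated at 100000 nM, with a range from 50000 nM to 200000 nM.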

Compound 4, half-maximal cytotoxic concentration: 95500 nM
Compound 4: middle estimate off by 1.0-fold (0.02 log units), on the high side; the measured number falls inside the stated range.
By their numbers in this assay, from the lowest: compounds 1, 3 and 4 (each within the scatter of the next). At a limit, above all of these: compound 2.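

Among the compounds shown here, the first step that can be read at this position is a 1.0-fold higher number from compound 1 to compound 4 (0.02 log units; within the scatter) in this assay, with hydrogen in place of benzyl on the amide-type nitrogen. The step lies within the scatter, so on this core the nitrogen carries either two benzyl groups or one with no difference that this assay can resolve, and the amide hydrogen brings no measurable shift in the tolerated concentration. Compound 2 stands at a limit, not a number, and adds nothing to this step: the limit of > 100000 nM in this assay, at which 1 of the 4 values shown sits.

What the remaining benzyl itself contributes stays open, since no compound shown replaces it on this core. Nor do the compounds shown tell whether an amine, a carboxylic acid or a longer chain on that nitrogen would leave the number where it is.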